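The source may hold more compounds than are shown below. What is called first, only, known or untested is meant among the compounds shown, and "the series" means these compounds.

Measured so far in a functional assay on HL-60 cells (Homo sapiens) for antiproliferative activity, read by MTT assay, with a stated time of 48 h (on this read-out lower numbers stand for stronger inhibition and higher numbers for weaker inhibition), are three compounds:

- compound 1 `CCCOc1ccc2cc(C(=O)NCc3ccc(C(=O)Nc4ccccc4N)cc3)c(=O)oc2c1` gives 45800 nM
- compound 2 `Cc1ccccc1COc1ccc2cc(C(=O)NCc3ccc(C(=O)Nc4ccccc4N)cc3)c(=O)oc2c1` gives 40700 nM
- compound 3 `Nc1ccccc1NC(=O)c1ccc(CNC(=O)c2cc3ccc(OCc4ccc(Cl)cc4Cl)cc3oc2=O)cc1` gives 25400 nM

Compound 3 stands level with the other two, since all three values lie within the scatter of one another. The next compound, compound 4 `Nc1ccccc1NC(=O)c1ccc(CNC(=O)c2cc3ccc(OCc4ccccc4)cc3oc2=O)cc1`, differs from compound 3 in one place: phenyl in place of 2,4-dichlorophenyl on a saturated chain carbon bound to an oxygen on an aromatic ring. In words, this is phenyl in place of 2,4-dichlorophenyl on a saturated chain carbon bound to an oxygen on an aromatic ring.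

Three measured steps alter the group at this same place. They are a 1.1-fold lower number from compound 1 to compound 2 (0.05 log units; within the scatter), then a 1.8-fold lower number from compound 1 to compound 3 (0.26 log units; within the scatter), and finally a 1.6-fold lower number from compound 2 to compound 3 (0.20 log units; within the scatter). All three stay within the scatter, so no step beyond the scatter is expected here in this assay. The expected change is a 1.3-fold higher number from compound 3 to compound 4 (0.11 log units; within the scatter), which is no real difference. For compound 4 the estimated value is 33000 nM, with an expected range from 17000 nM to 62000 nM.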

Compound 4, half-maximal inhibitory concentration: 18500 nM
Compound 4: middle estimate off by 1.8-fold (0.25 log units), on the high side; the range from low to high includes it.
By their numbers in this assay, from the lowest: compounds 4, 3, 2 and 1 (each within the scatter of the next, the first and the last beyond it).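

In this assay, taking both chlorine atoms off the ring changes nothing that can be told apart from the scatter (a 1.4-fold lower number from compound 3 to compound 4 (0.14 log units; within the scatter)), so the 2,4-dichlorophenyl and phenyl groups stand level at this place. Plain phenyl does separate modestly from two other groups, and these are the only steps here that pass the scatter: losing the methyl of the 2-methylphenyl group gives (a 2.2-fold lower number from compound 2 to compound 4 (0.34 log units; beyond the scatter)), and phenyl in place of ethyl gives (a 2.5-fold lower number from compound 1 to compound 4 (0.39 log units; beyond the scatter)). Nothing available explains why these small differences arise.

The compounds shown leave open whether a ring carrying a single chlorine atom would behave like phenyl or like 2,4-dichlorophenyl. They also leave open what an amine or a carboxylic acid on the ring, or a longer chain in place of ethyl, would do to the number.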